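From isopropyl to benzyl on a ring nitrogen

The source may report more compounds than this note shows. Statements on the series, on what has been measured and on what is new or still open speak of the compounds shown alone.

Compound 1 `O=C(C1CC12CCN(C1CCOCC1)CC2)N1CCCN(C2CCC2)CC1` gives 0.18
Compound 2 `CC(C)N1CCC2(CC1)CC2C(=O)N1CCN(C2CCCCC2)CC1` gives 0.74

In a physicochemical assay for lipophilicity, read by HPLC, using the shake flask method, measured as octanol-water partition (on this read-out higher numbers stand for higher lipophilicity and lower numbers for lower lipophilicity), compound 2 has the higher of the two numbers, at 0.74 on this scale, and compound 1 lies lower, with a gap beyond the scatter. Going by the values given here, no pair of measured compounds differs in just one place, so the data hold no direct guide to the next change.

Compound 3 `O=C(C1CC12CCN(Cc1ccccc1)CC2)N1CCN(C2CCCCC2)CC1` has benzyl in place of isopropyl on an amine nitrogen in a ring and is otherwise the same as compound 2. The expected move in this assay is upward and beyond the scatter, estimated as a number 1.16 log units higher from compound 2 to compound 3 (beyond the scatter) on judgement alone. For compound 3 the estimate is 1.9 as the central value, with 1.3 to 2.5 as the expected range.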

Compound 3, distribution coefficient: 2.81
Compound 3: the middle estimate sits 0.91 log units below what was measured; measured number above the stated range.
By their numbers in this assay, from the lowest: compound 1; then compound 2; then compound 3.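

In this assay, going by these compounds alone, compound 2 and compound 3 form the first pair that differs in only one place, and benzyl in place of isopropyl gives a number 2.07 log units higher from compound 2 to compound 3 (beyond the scatter) as its step. This shows that the group on this amine nitrogen in a ring can shift the read-out strongly, which compound 1 and compound 2 could not show, as they differ in more than one place. Nothing measured here explains the size of the step.

As far as these compounds go, whether the step follows the aromatic ring of benzyl or its larger count of carbon atoms stays open, and a butyl chain or a pyridylmethyl group at this nitrogen would help separate the two. Also open, from the compounds shown here alone, is whether the same change would give a similar step on the core of compound 1.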